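Amide variation on a dimethoxy-indane acetamide series

This account rests on a few compounds, and the source may have more. Where it says the series, first, only, none or still open, it means among the compounds named here.

Measured so far:
compound 1 `CCCNC(=O)CC1CCc2cc(OC)c(OC)cc21` — 22.2%
compound 2 `COc1cc2c(cc1OC)C(CC(=O)NCc1ccccc1)CC2` — 30.6%

Both numbers come from a functional assay on the whole organism (strain Wistar) for inhibition, with Rattus norvegicus as the target, read by paw edema, with stated times of 60 min and 6 h, at a dose of 100 mg/kg by the oral route; a lower number here means less inhibition, a higher number more inhibition at the dose given (going by the name of the read-out). In this assay compound 1 gives 22.2% and compound 2 gives 30.6%. Going by the values given here, the one step between them, phenyl in place of ethyl on a saturated chain carbon bound to an amide-type nitrogen, is a number 8.4 percentage points higher from compound 1 to compound 2 (within the scatter), so the two compounds lie within the scatter of each other and the number of compound 2 cannot be called higher than that of compound 1 on these numbers.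

Compound 3 `COc1cc2c(cc1OC)C(CC(=O)N1CCCCC1)CC2` is not yet measured in this assay. It differs from compound 2 in one place: piperidin-1-yl in place of benzylamino on a carbonyl carbon. Among the compounds with values here, the only measured step that bears on this change is the one on the same amide-type nitrogen, a number 8.4 percentage points higher from compound 1 to compound 2 (within the scatter), which stayed within the scatter. Within the data shown here, that step exchanged one group on the chain carbon for another and kept the amide hydrogen; the present change also takes the hydrogen-bond donor away, which no measured pair covers. Nothing in the two numbers points to a step in either direction, so compound 3 is expected to give a result close to compound 2, with the step of a number 2.6 percentage points lower from compound 2 to compound 3 (within the scatter) estimated to lie within the scatter. For compound 3 the expected value in this assay is 28%, estimated to fall between 10% and 45%.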

Compound 3, a percentage reported as inhibition, in the whole organism at one dose (the size of the read-out at that dose, not a potency): 31.5%
Estimate against measurement, compound 3: 3.5 percentage points below, within the range that was stated.
By their numbers in this assay, from the lowest: compounds 1, 2 and 3 (each within the scatter of the next).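

In this assay the place on the carbonyl carbon now carries a tertiary amide as well, and piperidin-1-yl in place of benzylamino comes to a number 0.9 percentage points higher from compound 2 to compound 3 (within the scatter), while the same group in place of propylamino comes to a number 9.3 percentage points higher from compound 1 to compound 3 (within the scatter). The loss of the hydrogen-bond donor, which the earlier pair did not cover, and the replacement of an open chain or a benzyl group by a six-membered non-aromatic ring therefore leave all three compounds within the scatter of each other at this single dose, so this read-out does not separate amides with and without the amide hydrogen in this small set. Nothing available on these compounds offers an explanation for this result.

The compounds shown leave open whether a ring with a second hetero atom, such as morpholin-4-yl or piperazin-1-yl, or a free carboxylic acid in place of the amide would move the number beyond the scatter. They also leave open what happens when the methoxy groups on the shared core are exchanged for other groups, or when the saturated chain carbon before the carbonyl is extended to a longer chain.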